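Working notes: compound 4 against compounds 1 to 3

The source may hold more compounds than are shown below. What is called first, only, known or untested is meant among the compounds shown, and "the series" means these compounds.

Compound 1 `CCCCCCCCCCCC(=O)N[C@H](CCC(=O)NCCCCCN)C(=O)O`: in a functional assay on HEK293 cells for agonist activity at Nucleotide-binding oligomerization domain-containing protein 1 (Homo sapiens), read by spectrophotometry (on this read-out higher numbers stand for an effect only at larger amounts of compound and lower numbers for an effect already at smaller amounts), compound 1 gives > 100 nM, which is a limit of the assay, not a number.
Compound 2 `CCCCCCCCCCCC(=O)N[C@H](CCC(=O)N[C@H](CCCCN)C(=O)O)C(=O)O`: in this assay compound 2 gives > 100 nM, again a limit.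
Compound 3 `CCCCCCCCCCCC(=O)N[C@H](CCC(=O)NCCCC[C@@H](N)C(=O)O)C(=O)O`: in this assay compound 3 gives 0.37 nM.

For the measured compounds named here, compound 3 holds the only number in the set; the other two values sit at the limit of > 100 nM in this assay, at which 2 of the 3 values shown sit. Compound 4 `CCCCCCCCCCCC(=O)N[C@H](CCC(=O)N[C@@H](CCCCN)C(=O)O)C(=O)O` keeps the atoms of compound 3, joined differently: a group of 9 heavy atoms (6 carbon, 1 nitrogen, 2 oxygen; no ring) in place of a group of 9 heavy atoms (6 carbon, 1 nitrogen, 2 oxygen; no ring), on an amide-type nitrogen. The measured steps that bear on this are an at least 270-fold lower number from compound 1 to compound 3 (2.43 log units; beyond the scatter) and an at least 270-fold lower number from compound 2 to compound 3 (2.43 log units; beyond the scatter), both large, whereas a step that the two limits leave unreadable from compound 1 to compound 2. Compound 4 reverses the placement that distinguished compound 3 from compound 2, so a large rise in the number is expected, a 270-fold higher number from compound 3 to compound 4 (2.43 log units; beyond the scatter), with a fair chance that only a limit is reported. Compound 4 is therefore estimated at 100 nM, range 5 nM to 2000 nM.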

Compound 4, half-maximal effective concentration: 0.57 nM
Compound 4: the middle estimate sits 180-fold (2.24 log units) above what was measured; the whole stated range lies above it.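

In this assay the 5-amino-1-carboxypentyl group on the amide-type nitrogen matches the group it replaces (a 1.5-fold higher number from compound 3 to compound 4 (0.19 log units; within the scatter)). Carboxy on the chain carbon bound to that nitrogen can therefore carry the effect (an at least 170-fold lower number from compound 1 to compound 4 (2.24 log units; beyond the scatter)), which compound 2 did not show. The large gap at this carbon (an at least 170-fold lower number from compound 2 to compound 4 (2.24 log units; beyond the scatter)) goes with configuration, not with carboxy placement: the fact that compounds 2 and 4 differ only in the configuration as drawn.

Going by these compounds, whether a hydroxyl in place of the amine of this group would hold such a value stays open. So does the effect of a shorter chain in the group.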